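The compounds below may be only part of what the source reports. "The series", "measured", "known", "first", "only" and "open" are said of these compounds alone.

Measured so far in a functional assay on NCI-H2122 cells (Homo sapiens) for inhibition, read by microscopy, with a stated time of 10 days; a lower number here means a stronger inhibitor, a higher number a weaker inhibitor:
compound 1 `Cc1nn(C)c2c1C(c1ccccc1)C(C#N)=C(N)O2`, 9100 nM
compound 2 `Cn1nc(-c2ccccc2)c2c1OC(N)=C(C#N)C2c1ccccc1`, > 10000 nM (a limit of the assay, not a number)
compound 3 `COc1ccc(-c2nn(-c3ccccc3)c3c2C(c2ccc(F)cc2)C(C#N)=C(N)O3)cc1OC`, 7600 nM

In this assay compound 1 gives 9100 nM and compound 3 gives 7600 nM. For compound 2 only a limit is known, > 10000 nM, and no number. This is the limit of > 10000 nM in this assay, at which 1 of the 3 values shown sits. Among the measured compounds shown here, the single one-place step that has been measured, an at least 1.0-fold higher number from compound 1 to compound 2 (0.04 log units; that floor lies within the scatter), puts phenyl in place of methyl on an aromatic carbon and ends at that limit, so its true size is not known.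

Compound 4 `Cn1nc(-c2ccccc2)c2c1OC(N)=C(C#N)C2c1cccc(Br)n1` differs from compound 2 in one place: 6-bromopyridin-2-yl in place of phenyl on a saturated ring carbon. For the measured compounds named here, no measured pair differs only at that saturated ring carbon, so no measured step bears directly on this change; compound 3 carries a different group there but differs from compound 2 in other places as well, and the values of compound 1 and compound 3 are all the data offer. With nothing pointing either way, the expected step in this assay from compound 2 to compound 4 is none beyond the scatter, a step that the limit leaves unreadable from compound 2 to compound 4, and the measurement may again return only a limit. Compound 4 is therefore estimated at 12000 nM, with a range of 4000 nM to 40000 nM.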

Compound 4, half-maximal inhibitory concentration: 1700 nM
Beside the measured number, compound 4's estimate is 7.1-fold (0.85 log units) above it, outside the stated range (below it).
By their numbers in this assay, from the lowest: compound 4; then compounds 3 and 1 (each within the scatter of the next). At a limit, above all of these: compound 2.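

Among the compounds shown here, compound 4 gives the first reading of the saturated ring carbon on its own, and this position turns out not to be silent in this assay: 6-bromopyridin-2-yl in place of phenyl there gives an at least 5.8-fold lower number from compound 2 to compound 4 (0.76 log units; beyond the scatter). For the compounds shown here, this step lies beyond the scatter, whereas the only earlier step, made on an aromatic carbon, showed nothing beyond it. The true size of the new step remains unknown, and the printed figure is only a floor, because compound 2 has a limit of the assay and not a number: the limit of > 10000 nM in this assay, at which 1 of the 4 values shown sits.

The entering group brings the ring nitrogen and the bromine together, so the compounds shown do not tell whether one of them accounts for the step, or both; a plain pyridin-2-yl group, or a 6-chloropyridin-2-yl or 6-methylpyridin-2-yl group, at this carbon would separate the two. Going by these compounds alone, also open is whether the same change carries over to the core of compound 1, with its methyl group on the aromatic carbon, since only one pair speaks to this position.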